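Swapping chloro for trifluoromethyl: clearance of compound 3

The source may report more compounds than this note shows. Statements on the series, on what has been measured and on what is new or still open speak of the compounds shown alone.

Values so far in an ADME assay on microsomes from liver (Mus musculus) for metabolic stability; a higher number here means faster removal of the compound, a lower number slower removal 
compound 1 `CC(C(=O)O)c1nn(Cc2cn3cc(OCC4CC4)c(Cl)cc3n2)c2ccccc2c1=O`: 80 mL/min/kg 
compound 2 `C[C@@H](C(=O)O)c1nn(Cc2cn3cc(OCC4CC4)c(Cl)cc3n2)c2ccccc2c1=O`: < 55 mL/min/kg (a limit)

For the measured compounds named here, compound 1 gives 80 mL/min/kg as the only exact number so far. Compound 2 has < 55 mL/min/kg as a limit. Compound 3 `CC(C(=O)O)c1nn(Cc2cn3cc(OCC4CC4)c(C(F)(F)F)cc3n2)c2ccccc2c1=O` carries trifluoromethyl in place of chloro on an aromatic carbon, ortho to a cyclopropylmethoxy group (trifluoromethyl in place of chloro on an aromatic carbon). Going by the values given here, the one measured step, an at least 1.4-fold lower number from compound 1 to compound 2 (0.16 log units; that floor lies within the scatter), only changes a drawn configuration at another place, so it offers no guide to this swap. No change beyond the scatter is therefore expected. The estimated 1.1-fold lower number from compound 1 to compound 3 (0.06 log units; within the scatter) stays within that scatter. Compound 3 is expected at 70 mL/min/kg (estimated range 35 mL/min/kg to 130 mL/min/kg).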

Compound 3, clearance: < 60 mL/min/kg
Compound 3 ended at the assay's limit; the forecaster's own chance of this, stated with the estimate: 25%; at least 1.1-fold (0.06 log units) between middle value and limit.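

In this assay, trifluoromethyl in place of chloro on this aromatic carbon, ortho to a cyclopropylmethoxy group, gives an at least 1.3-fold lower number from compound 1 to compound 3 (0.12 log units; that floor lies within the scatter). This is the first change shown at this position, and it brings no sign of faster removal, although that floor does not establish a real drop. The true size of the step stays unknown because the result for compound 3 is a limit, not a number: the limit of < 60 mL/min/kg in this assay, at which 1 of the 3 values shown sits.

On these data alone, how a nitrile, a methyl group or a plain hydrogen would behave at this position remains open. So does the effect of a defined configuration on compound 3.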